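The source may report more compounds than this note shows. Statements on the series, on what has been measured and on what is new or still open speak of the compounds shown alone.

Compound 1 `Cc1ccccc1CN1CCc2c(sc(NC(=O)c3ccccc3Cl)c2C(N)=O)C1`: in a functional assay on HL-60 cells (Homo sapiens) for antiproliferative activity, with a stated time of 24 h (a higher number here means a weaker inhibitor, a lower number a stronger inhibitor), compound 1 reaches only the limit > 50000 nM.
Compound 2 `NC(=O)c1c(NC(=O)c2ccccc2Cl)sc2c1CCN(Cc1ccccc1F)C2`: in this assay compound 2 gives 21800 nM.
Compound 3 `COc1ccccc1NC(=S)N1CCc2c(sc(NC(=O)c3ccccc3Cl)c2C(N)=O)C1`: in this assay compound 3 gives 40900 nM.

Compound 3 holds the higher of the two numbers recorded, while the value of compound 1 is a limit rather than a number (the limit of > 50000 nM in this assay, at which 1 of the 3 values shown sits). Its gap to compound 2, a 1.9-fold higher number from compound 2 to compound 3 (0.27 log units; within the scatter), lies within the scatter, so the two cannot be ordered. The step of an at least 1.2-fold lower number from compound 1 to compound 3 (0.08 log units; that floor lies within the scatter) is bounded only by the limit of compound 1, and an at least 2.2-fold lower number from compound 1 to compound 2 (0.36 log units; beyond the scatter) concerns a change on the benzyl ring of the core.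

Compound 4 `NC(=O)c1c(NC(=O)c2ccccc2Cl)sc2c1CCN(C(=S)Nc1c(Cl)cccc1Cl)C2` differs from compound 3 in one place: 2,6-dichlorophenyl in place of 2-methoxyphenyl on an amide-type nitrogen. Going by the values given here, none of the measured steps touches the ring on this amide-type nitrogen; the steps recorded exchange the whole substituent on the ring amine, not the aryl group of the thiourea. The numbers for compounds 2 and 3 sit close together, and compound 1 sits at the limit, so the shared core itself is a weak inhibitor in this assay. For compound 4 a number near that of compound 3 is therefore expected, with the step of a 1.0-fold lower number from compound 3 to compound 4 (0.01 log units; within the scatter) estimated to stay within the scatter. The estimate for compound 4 is 40000 nM, between 15000 nM and 110000 nM.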

Compound 4, half-maximal inhibitory concentration: 3950 nM
Estimate against measurement, compound 4: 10-fold (1.01 log units) above; the measured number lies below the stated range.
By their numbers in this assay, from the lowest: compound 4; then compounds 2 and 3 (each within the scatter of the next). At a limit, above all of these: compound 1.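

In this assay, going by these compounds alone, the group on the amide-type nitrogen proves to be a place where activity changes markedly, which no earlier step could show: 2,6-dichlorophenyl in place of 2-methoxyphenyl gives a 10-fold lower number from compound 3 to compound 4 (1.02 log units; beyond the scatter). The shared core therefore does not by itself hold these compounds to weak inhibition, and compound 4 also separates clearly from the compounds with a substituted benzyl group on the ring amine, with a 5.5-fold lower number from compound 2 to compound 4 (0.74 log units; beyond the scatter) and an at least 12-fold lower number from compound 1 to compound 4 (1.10 log units; beyond the scatter). That last step is only a floor, since the value of compound 1 is a limit and not a number: the limit of > 50000 nM in this assay, at which 1 of the 4 values shown sits.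

The step from compound 3 to compound 4 removes the methoxy group and brings in both chlorines at once, so the compounds shown do not tell which part of the exchange carries it. Still open, going by these compounds, is how plain phenyl, 2-chlorophenyl or 2,6-dimethylphenyl would read on the same nitrogen, and whether a carbonyl in place of the thiocarbonyl would keep the lower number of compound 4.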